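The source may report more compounds than this note shows. Statements on the series, on what has been measured and on what is new or still open speak of the compounds shown alone.

Measured so far in a functional assay on A549 cells (Homo sapiens) for inhibition, read by MTT assay, with a stated time of 72 h; on this read-out higher numbers stand for weaker inhibition and lower numbers for stronger inhibition:
compound 1, `C=CC(=O)Nc1cc(Nc2nc3c(c(-c4cn(C)c5ccccc45)n2)CSCC3)c(OC)cc1N(C)CCN(C)C`, gives 506 nM;
compound 2, `C=C(Cl)C(=O)Nc1cc(Nc2nc3c(c(-c4cn(C)c5ccccc45)n2)CSCC3)c(OC)cc1N(C)CCN(C)C`, gives 716 nM;
compound 3, `C=CC(=O)Nc1cc(Nc2nc3c(c(-c4cn(C)c5ccc(F)cc45)n2)CS(=O)(=O)CC3)c(OC)cc1N(C)CCN(C)C`, gives 4640 nM.

Compound 2 differs from compound 1 in one place: chloro in place of hydrogen on a double-bonded chain carbon bound to a carbonyl carbon. That change gave a 1.4-fold higher number from compound 1 to compound 2 (0.15 log units; within the scatter), so on this read-out the two compounds cannot be told apart. Compound 3 carries a different core; how its core differs from that of compound 1 is not broken down here, and its number stands clearly above those of compound 1 and compound 2.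

Compound 4, `C=C(Cl)C(=O)Nc1cc(Nc2nc3c(c(-c4cn(C)c5ccc(F)cc45)n2)CS(=O)(=O)CC3)c(OC)cc1N(C)CCN(C)C`, has not yet been measured in this assay. It stands to compound 3 as compound 2 stands to compound 1: chloro in place of hydrogen on a double-bonded chain carbon bound to a carbonyl carbon, at the same place in both pairs, so it is the same change. Because the earlier example of this change gave a 1.4-fold higher number from compound 1 to compound 2 (0.15 log units; within the scatter), a step of similar size is expected here: a 1.4-fold higher number from compound 3 to compound 4 (0.15 log units; within the scatter). Compound 4 is therefore estimated at 6500 nM, most likely falling between 3500 nM and 12000 nM.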

Compound 4, half-maximal inhibitory concentration: 3180 nM
For compound 4 the middle estimate is 2.0-fold (0.31 log units) above the measured one; the whole stated range lies above it.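

In this assay the swap of hydrogen for chloro on a double-bonded chain carbon bound to a carbonyl carbon gave a 1.5-fold lower number from compound 3 to compound 4 (0.16 log units; within the scatter), so compound 3 and compound 4 cannot be told apart on this read-out. Set beside the earlier example, the change carries over from one core to the other without a detectable difference, since the two steps point in opposite directions only on paper: the same change on two cores in this assay, a 1.4-fold higher number (0.15 log units; within the scatter) from compound 1 to compound 2 and a 1.5-fold lower number (0.16 log units; within the scatter) from compound 3 to compound 4, 2.1-fold (0.31 log units) apart, within the scatter of two such steps. This shows that on these two cores the swap leaves the number within the usual scatter, but it does not show a real rise or fall on either core, and it says nothing about cores beyond these two.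

The compounds shown leave open what other groups on that same carbon would do, such as fluoro, methyl or a nitrile. They also leave open whether a longer chain or an amine at that carbon would move the number beyond the scatter on either core.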